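From a Benzyl Amide to a Biphenyl Anilide

The compounds below may be only part of what the source reports. "The series", "measured", "known", "first", "only" and "open" are said of these compounds alone.

Compound 2 `O=C(COc1ccc2cc(C(O)(C(F)(F)F)C(F)(F)F)c(O)cc2c1)NCc1ccccc1` reaches only a limit in an assay on isolated protein for inhibition of receptor-type tyrosine-protein phosphatase C (Homo sapiens), read by spectrophotometry; on this read-out lower numbers stand for stronger inhibition and higher numbers for weaker inhibition: in this assay compound 2 gives > 20000 nM, which is a limit of the assay and not a number. Compound 1 `COc1ccc(CNC(=O)COc2ccc3cc(C(O)(C(F)(F)F)C(F)(F)F)c(O)cc3c2)cc1OC` likewise gives only a limit, > 20000 nM. Among the measured compounds shown here, the step that the two limits leave unreadable from compound 1 to compound 2 is therefore unreadable, the only evidence being (the limit of > 20000 nM in this assay, at which 2 of the 2 values shown sit). Compound 3 `O=C(COc1ccc2cc(C(O)(C(F)(F)F)C(F)(F)F)c(O)cc2c1)Nc1ccc(-c2ccccc2)cc1` carries 4-phenylphenyl in place of benzyl on an amide-type nitrogen. For the measured compounds named here, no measured step here resolves beyond the limit, so none bears readably on this change. Compound 3 is expected to stay near the same limit, with the step that the limit leaves unreadable from compound 2 to compound 3 estimated as small. Compound 3 is estimated at 30000 nM, in the range 5000 nM to 100000 nM.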

Compound 3, half-maximal inhibitory concentration: 3400 nM
Beside the measured number, compound 3's estimate is 8.8-fold (0.95 log units) above it, and the stated range ends above it.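

In this assay, 4-phenylphenyl on the amide-type nitrogen brings the first readable inhibition in this series, with an at least 5.8-fold lower number from compound 2 to compound 3 (0.76 log units; beyond the scatter) and an at least 5.8-fold lower number from compound 1 to compound 3 (0.76 log units; beyond the scatter). So this position can respond to a change, which the two benzyl-type amides could not show. Both steps are minimum sizes, because compound 1 and compound 2 sit at a limit of the assay: the limit of > 20000 nM in this assay, at which 2 of the 3 values shown sit.

On these data alone, the change adds a second ring and removes the chain carbon of benzyl together, so which of these matters remains open. A plain phenyl or a 4-phenylbenzyl group on the same nitrogen would separate the two.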